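The compounds below may be only part of what the source reports. "The series", "measured", "known", "first", "only" and "open" are said of these compounds alone.

Going by the values given here, compound 3 `CCCCCCCCCCCC[C@@H](O)[C@H]1CC[C@H]([C@H](O)CCCCCCCCCCNCc2ccnn2C)O1` carries the lowest of the three numbers so far in a functional assay on MCF7 cells (Homo sapiens) for inhibition, read by sulforhodamine B assay, with a stated time of 48 h; a lower number here means a stronger inhibitor of growth, a higher number a weaker inhibitor of growth: compound 3 gives 1700 nM, while compound 1 `CCCCCCCCCCCC[C@@H](O)[C@H]1CC[C@H]([C@H](O)CCCCCCCCCCNC(=O)c2ccnn2C)O1` gives 3240 nM and compound 2 `CCCCCCCCCCCC[C@@H](O)[C@H]1CC[C@H]([C@H](O)CCCCCCCCCCN(C)C(=O)c2ccnn2C)O1` gives 5010 nM. The step of a 1.9-fold lower number from compound 1 to compound 3 (0.28 log units; within the scatter) lies within the scatter, so compound 3 and compound 1 cannot be ordered; only against compound 2 does compound 3 stand apart, by a 2.9-fold lower number from compound 2 to compound 3 (0.47 log units; beyond the scatter), a modest gap. The step of a 1.5-fold higher number from compound 1 to compound 2 (0.19 log units; within the scatter) is also within the scatter.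

Compound 4 `CCCCCCCCCCCC[C@@H](O)[C@H]1CC[C@H]([C@H](O)CCCCCCCCCCOC(=O)c2ccnn2C)O1` is the next member, not yet measured. Against compound 3 the change is ((1-methyl-1H-pyrazol-5-yl)carbonyl)oxy in place of ((1-methyl-1H-pyrazol-5-yl)methyl)amino on a saturated chain carbon, ten or more bonds along the chain from an oxygen on a saturated carbon and a saturated ring carbon. This reverses the direction of the change from compound 1 to compound 3 by bringing back a carbonyl, and it leaves no hydrogen-bond donor. Among the compounds with values here, the steps that bear on it are a 1.9-fold lower number from compound 1 to compound 3 (0.28 log units; within the scatter), within the scatter, and a 2.9-fold lower number from compound 2 to compound 3 (0.47 log units; beyond the scatter), modest; both put the carbonyl-bearing compounds at higher numbers than compound 3. A step back toward the numbers of compound 1 and compound 2 is therefore expected, in this assay of about a 2.1-fold higher number from compound 3 to compound 4 (0.31 log units; beyond the scatter), small and likely within the scatter. Compound 4 is estimated at 3500 nM, in the range 1500 nM to 8000 nM.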

Compound 4, concentration for 50% growth inhibition: 22900 nM
Compound 4: the middle estimate sits 6.5-fold (0.82 log units) below what was measured; measured number outside the range, above it.
By their numbers in this assay, from the lowest: compounds 3, 1 and 2 (each within the scatter of the next, the first and the last beyond it); then compound 4.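

In this assay this chain position, nearly flat across the nitrogen-linked compounds, turns out to be sensitive to the linking atom: the ((1-methyl-1H-pyrazol-5-yl)carbonyl)oxy group gives a 13-fold higher number from compound 3 to compound 4 (1.13 log units; beyond the scatter) and also a 7.1-fold higher number from compound 1 to compound 4 (0.85 log units; beyond the scatter) and a 4.6-fold higher number from compound 2 to compound 4 (0.66 log units; beyond the scatter). The carbonyl alone does not separate compound 4, since compound 1 and compound 2 carry it too, and the missing amide hydrogen alone does not either, since compound 2 also lacks it. No measurement here gives a reason for the jump.

Going by these compounds, it remains open whether a (1-methyl-1H-pyrazol-5-yl)methoxy group, an ether on the same saturated chain carbon, would stay with compound 3 or move toward compound 4. A ((1-methyl-1H-pyrazol-5-yl)carbonyl)thio group would likewise test whether oxygen itself matters.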